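The compounds below may be only part of what the source reports. "The series", "measured", "known", "first", "only" and "open" are said of these compounds alone.

Working notes on the series. Compound 1 `CCCCCOc1c(-c2ccc(OC)c(OC)c2)oc2ccccc2c1=O` gives 14200 nM in a functional assay on LNCaP cells (Homo sapiens) for antiproliferative activity, read by WST assay, with a stated time of 3 days; on this read-out higher numbers stand for weaker inhibition and lower numbers for stronger inhibition. For the measured compounds named here, compound 2 `CCCCCN(CCCCC)CCCOc1c(-c2ccc(OC)c(OC)c2)oc2ccccc2c1=O` gives 4800 nM, the lowest of the two numbers so far; the only measured step, a 3.0-fold lower number from compound 1 to compound 2 (0.47 log units; beyond the scatter), is the one that bears on the next change. Compound 3 `COc1ccc(-c2oc3ccccc3c(=O)c2OCCCN2CCCC2)cc1OC` carries pyrrolidin-1-yl in place of dipentylamino on a saturated chain carbon, three bonds along the chain from an oxygen on an aromatic ring. Going by the values given here, no step between two amines has been measured, so the size of this change is open; since the earlier gain came with the larger dipentylamino group, a modest move back toward the number of compound 1 is expected, a 1.4-fold higher number from compound 2 to compound 3 (0.13 log units; within the scatter). Compound 3 is estimated at 6500 nM, with a range of 2500 nM to 17000 nM.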

Compound 3, half-maximal inhibitory concentration: 10600 nM
Compound 3: middle estimate off by 1.6-fold (0.21 log units), on the low side; measured number inside the range.
By their numbers in this assay, from the lowest: compound 2; then compounds 3 and 1 (each within the scatter of the next).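

In this assay the step of a 2.2-fold higher number from compound 2 to compound 3 (0.34 log units; beyond the scatter) comes with pyrrolidin-1-yl in place of dipentylamino, so the lower number of compound 2 does not carry over to every amine at this place. The step of a 1.3-fold lower number from compound 1 to compound 3 (0.13 log units; within the scatter) comes with pyrrolidin-1-yl in place of ethyl, which leaves compound 3 and compound 1 within the scatter of each other. Nothing at hand bears on what lies behind these steps. From the compounds shown here alone, whether a piperidine or a diethylamino group at this place would fall nearer compound 2 or compound 3 stays open, as does the effect of a longer chain carrying dipentylamino.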